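The source may report more compounds than this note shows. Statements on the series, on what has been measured and on what is new or still open speak of the compounds shown alone.

Working notes on the series, in a functional assay on the whole organism (strain Sprague-Dawley) for inhibition, with Rattus norvegicus as the target; on this read-out higher numbers stand for an effect only at larger amounts of compound and lower numbers for an effect already at smaller amounts.

Compound 2 `COc1cccc2c(=O)c(-c3nn[nH]n3)c[nH]c12` gives 0.312 mg/kg in this assay. That is the lowest of the two numbers recorded; the nearest is compound 3 `FC(F)(F)c1cccc2cc(-c3nn[nH]n3)cnc12`, which gives 25 mg/kg in this assay, a gap well beyond the scatter. Compound 1 `COc1ccc2c(O)c(C(=O)O)cnc2c1` is recorded only as a limit, > 100 mg/kg in this assay, as noted in the limit of > 100 mg/kg in this assay, at which 1 of the 3 values shown sits. Among the compounds with values here, no pair among the three measured compounds differs in a single place, so no measured step is available to lean on.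

Compound 4 `O=c1c(-c2nn[nH]n2)c[nH]c2c(F)cccc12` has not yet been measured in this assay. It differs from compound 2 in one place: fluoro in place of methoxy on an aromatic carbon. There is no measured step of this kind in the series, so the expectation rests on the position of compound 2 alone. A modest upward movement in the minimum effective dose, beyond the scatter, is expected, but nothing large. Compound 4 is thus estimated at 1 mg/kg in this assay, with a range from 0.3 mg/kg to 5 mg/kg, corresponding to an expected step of a 3.2-fold higher number from compound 2 to compound 4 (0.51 log units; beyond the scatter).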

Compound 4, minimum effective dose: 10 mg/kg
For compound 4 the middle estimate is 10-fold (1.00 log units) below the measured one, and the stated range ends below it.
By their numbers in this assay, from the lowest: compound 2; then compound 4; then compound 3. At a limit, above all of these: compound 1.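

In this assay, within the data shown here, this aromatic carbon, ortho to a fused ring and meta to a fused ring, is the first place where a single change can be read: fluoro in place of methoxy gives a large step (a 32-fold higher number from compound 2 to compound 4 (1.51 log units; beyond the scatter)). The number at this position therefore depends strongly on the group it carries, and on the shared core methoxy goes with the lower number of the two. Nothing in the data shown accounts for the size of this step.

Open, as far as these compounds go, is how an ethoxy, a hydroxy or an amine on the same carbon would compare with methoxy and fluoro. Also open, from the compounds shown here alone, is whether the same exchange on another carbon of this ring would give a step of similar size.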